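Methoxy in Place of Fluoro: What Compound 4 Might Show

This account rests on a few compounds, and the source may have more. Where it says the series, first, only, none or still open, it means among the compounds named here.

Compound 1 `OC[C@@]1(c2ccc(F)cc2)NC[C@@H](O)[C@@H]1O` gives in an assay on isolated protein for inhibition of alpha-galactosidase (Coffea arabica), tested at 1000 uM (a higher number here means more inhibition at the concentration tested (going by the name of the read-out), a lower number less inhibition), a read-out of 0%. Compound 2 `COc1ccc([C@]2(CO)NC[C@@H](O)[C@@H]2O)cc1`, which differs by methoxy in place of fluoro on an aromatic carbon, gives 7.5%, a step of a number 7.5 percentage points higher from compound 1 to compound 2 (within the scatter). Compound 3 `OC[C@@]1(c2cccc(F)c2)NC[C@@H](O)[C@@H]1O` gives 0%; it has the same atoms as compound 1 joined differently, and the difference between the two cores is not broken down here. Compound 4 `COc1cccc([C@]2(CO)NC[C@@H](O)[C@@H]2O)c1` carries the same kind of change as compound 2, (methoxy in place of fluoro on an aromatic carbon), but the methoxy stands meta to a group of 9 heavy atoms rather than para to it. For compound 4 the expected step is a number 5 percentage points higher from compound 3 to compound 4 (within the scatter), resting on the step of a number 7.5 percentage points higher from compound 1 to compound 2 (within the scatter) that the same kind of change gave. Compound 4 is thus estimated at 5%, between 0% and 20%.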

Compound 4, a percentage reported as inhibition, at one concentration (the size of the read-out at that concentration, not a potency): 1.6%
The estimate for compound 4 lay 3.4 percentage points above the measured number, and the stated range covers the measured number.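

In this assay methoxy in place of fluoro on an aromatic carbon gives a number 1.6 percentage points higher from compound 3 to compound 4 (within the scatter) and, set beside the earlier step, the change carries from one core to the other with no difference that can be told apart: the same change on two cores in this assay, a number 7.5 percentage points higher (within the scatter) from compound 1 to compound 2 and a number 1.6 percentage points higher (within the scatter) from compound 3 to compound 4, 5.9 percentage points apart, within the scatter of two such steps. For the compounds shown here, on neither core does the change give a step beyond the scatter, so the agreement shows only that both steps are small at the one concentration tested. It does not show that the change would carry over alike where a step is large enough to read, and it gives no potency.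

The compounds shown leave open how an amine or a carboxylic acid in place of fluoro would read in this assay. They also leave open what a longer chain on the methoxy oxygen would give.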